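This account rests on a few compounds, and the source may have more. Where it says the series, first, only, none or still open, it means among the compounds named here.

Of the compounds shown here, three have been measured in a functional assay on the whole organism for antagonist activity, with Mus musculus as the target; on this read-out higher numbers stand for an effect only at larger amounts of compound and lower numbers for an effect already at smaller amounts. There compound 1 (`Cc1cncn1CC#CC(C)N1CCCC1=O`) gives 2.5 mg/kg, and compound 2 (`CC1CCC(=O)N1CC#CCn1ccnc1`) gives 1.1 mg/kg. Compound 3 (`CC(=O)NCC#CCn1ccnc1`) is reported only as a limit, > 100 mg/kg.

Compound 4 (`CC(=O)NCC#CCn1cncc1C`) is compound 3 with a single change: methyl in place of hydrogen on an aromatic carbon. Going by the values given here, no measured pair isolates this change, so its size in this assay can only be expected. Compound 1 also carries a methyl on its ring and gives 2.5 mg/kg, but it differs from compound 4 in other places as well. Compound 2 gives 1.1 mg/kg without that methyl, and it too differs from compound 3 elsewhere. Neither compound shows what the methyl alone contributes. A modest shift towards smaller doses is therefore expected, though compound 4 may well remain at the limit of the assay. The expected change is an at least 1.4-fold lower number from compound 3 to compound 4 (0.15 log units; that floor lies within the scatter). For compound 4 the estimated value is 70 mg/kg, with an expected range from 20 mg/kg to 200 mg/kg.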

Compound 4, dose for half-maximal effect: 66 mg/kg
Estimate against measurement, compound 4: 1.1-fold (0.03 log units) above, and the stated range covers the measured number.
By their numbers in this assay, from the lowest: compound 2; then compound 1; then compound 4. At a limit, above all of these: compound 3.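

Compound 4 isolates a methyl in place of hydrogen on an aromatic carbon, next to the ring nitrogen and next to the ring atom that bears a group of 8 heavy atoms, and in this assay the change reads as an at least 1.5-fold lower number from compound 3 to compound 4 (0.18 log units; that floor lies within the scatter). Going by these compounds alone, this is the first view of what this methyl does alone, since compound 1 and compound 2 differ from compound 3 in other places as well, and compound 4 gives 66 mg/kg, a number rather than a limit. The size of the step can be stated only as a floor, which may understate it, because the value of compound 3 is a limit: the limit of > 100 mg/kg in this assay, at which 1 of the 4 values shown sits.

As far as these compounds go, it remains open whether an ethyl, a chlorine or a trifluoromethyl at this same place on the ring would move the number further than the methyl, or less far. From the compounds shown here alone, it also remains open whether the same methyl would change the number by a similar amount on the core of compound 2, where the value is not tied to a limit and a step could be read in full.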